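A few compounds are considered here, and "the series" means these few. Any claim that something is new, unique, unknown or untested is made for them only; others in the source may bear on it.

Compound 1 `C#CCNC1CCC(c2csc(C#C)n2)=C1C`: 2510 nM in a functional assay on NCI-H522 cells (Homo sapiens) for cytotoxicity, with a stated time of 3 days; a higher number here means a weaker inhibitor, a lower number a stronger inhibitor.
Compound 2 `C#Cc1nc(/C=C/C(=O)Nc2ccc(Cl)cc2)cs1`: 370 nM.
Compound 3 `C#CCNC(=O)c1csc(Br)n1`: > 40000 nM, which is a limit of the assay and not a number.

Compound 3 therefore stands at the limit of > 40000 nM in this assay, at which 1 of the 3 values shown sits, the only one of the three without a measured number. Compound 4 `C#CCNC(=O)c1cscn1` differs from compound 3 by hydrogen in place of bromo on an aromatic carbon. Going by the values given here, no pair of measured compounds differs in a single place, so the size of such a step has not been tried here. With only one heavy atom leaving and nothing but hydrogen entering, the step from compound 3 to compound 4 is expected to be none beyond the scatter, a step that the limit leaves unreadable from compound 3 to compound 4. Compound 4 is accordingly estimated at 60000 nM, within a range from 20000 nM to 200000 nM, and is expected most likely to be reported again only as a limit.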

Compound 4, half-maximal inhibitory concentration: > 40000 nM
Compound 4 ended at the assay's limit; the forecaster's own chance of this, stated with the estimate: 80%; the middle value lies beyond the limit too.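

The step between compound 3 and compound 4 cannot be read, as both stand at a limit and not at a number: the limit of > 40000 nM in this assay, at which 2 of the 4 values shown sit.

The compounds shown leave open whether hydrogen in place of bromo on this aromatic carbon changes activity at all.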